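Distribution Volumes of Three Related Carboxylic Acids

A few compounds are considered here, and "the series" means these few. Any claim that something is new, unique, unknown or untested is made for them only; others in the source may bear on it.

Compound 1 `CCC(C(=O)O)c1nn(Cc2cn3cc(OCC4CC4)c(Cl)cc3n2)c2ccccc2c1=O` was studied in an ADME assay on the whole organism (Mus musculus, strain CD1) for pharmacokinetics, read by LC-MS, with a stated time of 24 h, at a dose of 1 mg/kg by the intravenous route; on this read-out higher numbers stand for wider distribution into tissues and lower numbers for narrower distribution. In this assay compound 1 gives 60 L/kg. Compound 2 `CC(C(=O)O)c1nn(Cc2cn3cc(OCC4CC4)c(C(F)(F)F)cc3n2)c2ccccc2c1=O`, which shares the same core, was measured alongside it; in this assay compound 2 gives 94 L/kg. Of the two numbers, compound 1 stands lowest, and compound 2 sits closest to it, at a gap that falls within the scatter of this kind of measurement, so the two cannot be told apart on these data.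

Compound 3 `O=C(O)Cc1nn(Cc2cn3cc(OCC4CC4)c(Cl)cc3n2)c2ccccc2c1=O` has not yet been measured in this assay. Compared with compound 1, it differs in one place: hydrogen in place of ethyl on a saturated chain carbon bound to an aromatic carbon and a carbonyl carbon. For the measured compounds named here, both measured compounds carry an alkyl group on that saturated chain carbon, so there is no measured step that tells what hydrogen there does.

Given this, the step of a 1.2-fold lower number from compound 1 to compound 3 (0.08 log units; within the scatter) is expected to be small, with no direction beyond the scatter. Compound 3 is estimated to give about 50 L/kg in this assay, with a range from 20 L/kg to 125 L/kg.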

Compound 3, volume of distribution at steady state: 18 L/kg
Beside the measured number, compound 3's estimate is 2.8-fold (0.44 log units) above it; the whole stated range lies above it.
By their numbers in this assay, from the lowest: compound 3; then compounds 1 and 2 (each within the scatter of the next).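

In this assay, for the compounds shown here, the change from 1-carboxypropyl to carboxymethyl gives a 3.3-fold lower number from compound 1 to compound 3 (0.52 log units; beyond the scatter), the first step at this position that can be read, which shows that the ethyl on the saturated chain carbon bound to an aromatic carbon and a carbonyl carbon is not silent for this read-out. With hydrogen in place of ethyl, the number moves beyond the scatter of repeated measurements. This position can no longer be treated as one where the change makes no visible difference, although this rests on a single pair of compounds. No measurement offered here bears on why the number falls with this change.

On these data alone, whether a longer chain such as propyl, or a hydroxyl or an amine, on that same carbon would shift the distribution volume further, or in the opposite direction, remains open. Also open, as far as these compounds go, is whether the same change would give a step of similar size with trifluoromethyl in place of the chlorine of compound 3, since compound 2 differs from compound 1 and compound 3 in more than one place and gives no clean comparison.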